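This account rests on a few compounds, and the source may have more. Where it says the series, first, only, none or still open, it means among the compounds named here.

Measured in a functional assay on DU-145 cells (Homo sapiens) for inhibition, read by MTT assay, with a stated time of 72 h; a higher number here means a weaker inhibitor, a lower number a stronger inhibitor:
compound 1 `O=C1C=C(N2CCN(c3ccc(Cl)cc3)CC2)C(=O)c2ccccc21`: 29500 nM
compound 2 `COc1ccc(N2CCN(C3=CC(=O)c4ccccc4C3=O)CC2)cc1`: 46100 nM
compound 3 `O=C1C=C(N2CCN(c3cccc(Cl)c3)CC2)C(=O)c2ccccc21`: 8300 nM

Compound 3 has the lowest number of the three in this assay, and both steps leading to it lie beyond the scatter: a 3.6-fold lower number from compound 1 to compound 3 (0.55 log units; beyond the scatter) and a 5.6-fold lower number from compound 2 to compound 3 (0.74 log units; beyond the scatter). Compound 4 `Cc1cccc(N2CCN(C3=CC(=O)c4ccccc4C3=O)CC2)c1` differs from compound 3 in one group: methyl in place of chloro on an aromatic carbon. This is methyl in place of chloro on an aromatic carbon, meta to a large group.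

Within the data shown here, no measured step exchanges chloro for methyl. The closest is a 1.6-fold higher number from compound 1 to compound 2 (0.19 log units; within the scatter), with methoxy in place of chloro, which stays within the scatter, though it is a single pair with a different entering group. The modest step of a 3.6-fold lower number from compound 1 to compound 3 (0.55 log units; beyond the scatter), 3-chlorophenyl in place of 4-chlorophenyl, concerns a change that compound 4 does not make.

The expected step is a 1.6-fold higher number from compound 3 to compound 4 (0.19 log units; within the scatter), which stays within the scatter. For compound 4 the estimated value is 13000 nM, with an expected range of 5000 nM to 35000 nM.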

Compound 4, half-maximal inhibitory concentration: 7400 nM
For compound 4 the middle estimate is 1.8-fold (0.24 log units) above the measured one; the range from low to high includes it.
By their numbers in this assay, from the lowest: compounds 4 and 3 (each within the scatter of the next); then compounds 1 and 2 (each within the scatter of the next).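

In this assay, among these compounds, methyl in place of chloro on an aromatic carbon, meta to a large group, gives no separation (a 1.1-fold lower number from compound 3 to compound 4 (0.05 log units; within the scatter)), so the level of compound 3 does not depend on chloro at this place, which the earlier compounds, with only chloro and methoxy groups, could not show. The 3-methylphenyl group also stands clear of both 4-substituted phenyl groups (a 6.2-fold lower number from compound 2 to compound 4 (0.79 log units; beyond the scatter)) and (a 4.0-fold lower number from compound 1 to compound 4 (0.60 log units; beyond the scatter)), so the earlier gap is not limited to the 3-chlorophenyl compound. Nothing available accounts for the match between chloro and methyl at this place.

From the compounds shown here alone, whether this level holds with a nitrile, a trifluoromethyl or a carboxylic acid on the same carbon remains open. Also open, going by these compounds, is how a plain phenyl on the same nitrogen would compare.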